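Chloro on the benzyl group of compound 3

A few compounds are considered here, and "the series" means these few. Any claim that something is new, unique, unknown or untested is made for them only; others in the source may bear on it.

Compound 1 `O[C@]1(Cc2cc(-c3cn[nH]c3)on2)CC[C@@H](Cc2ccc(C(F)(F)F)cc2)CC1`: 67.5%
Compound 2 `O=C(c1cc(-c2cn[nH]c2)on1)N1CCC(Cc2ccccc2)CC1`: 0.2%
Compound 3 `O=C(c1cc(-c2ccc(=O)[nH]c2)on1)N1CCC(Cc2ccccc2)CC1`: 18.4%

All three were measured in an ADME assay on the whole organism (Rattus norvegicus, strain Sprague-Dawley) for pharmacokinetics, using cassette dosing, at a dose of 1 mg/kg by the oral route; a higher number here means that a larger share of the oral dose reaches the circulation, a lower number that a smaller share of the oral dose reaches the circulation. Compound 3 stands second highest, beyond the scatter from both compound 2 and compound 1. Compound 4 `O=C(c1cc(-c2ccc(=O)[nH]c2)on1)N1CCC(Cc2ccc(Cl)cc2)CC1` differs from compound 3 by one change: chloro in place of hydrogen on an aromatic carbon, that is, benzyl to 4-chlorobenzyl. Within the data shown here, the single measured step, a number 18.2 percentage points higher from compound 2 to compound 3 (beyond the scatter), lies at another place in the molecule, so it offers only a rough scale. Among the measured compounds shown here, no measured step tests chloro directly. A small upward change is therefore expected, possibly within the scatter. The expected change is a number 5.6 percentage points higher from compound 3 to compound 4 (within the scatter). Compound 4 is estimated at 24%, with an expected range of 8% to 45%.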

Compound 4, oral bioavailability: 9.3%
For compound 4 the middle estimate is 14.7 percentage points above the measured one; the range from low to high includes it.
By their numbers in this assay, from the lowest: compounds 2, 4 and 3 (each within the scatter of the next, the first and the last beyond it); then compound 1.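

Benzyl to 4-chlorobenzyl gives the first direct reading of this change in this assay, a number 9.1 percentage points lower from compound 3 to compound 4 (within the scatter) and so no effect of chloro at this place can be told apart from the scatter. The place para to a large group on the benzyl thus accepts chloro without a clear shift in this assay, on this single pair. No measured evidence bears on this result.

On these data alone, whether an amine, a methoxy group or a carboxylic acid at this place would move the number beyond the scatter stays open. Also open, as far as these compounds go, is whether chloro reads the same on compound 2.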